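A few compounds are considered here, and "the series" means these few. Any claim that something is new, unique, unknown or untested is made for them only; others in the source may bear on it.

In a functional assay on EA.hy 926 cells (Homo sapiens) for cytotoxicity, read by MTT assay, with stated times of 24 h and 12 h (a lower number here means that less compound is needed, a higher number that more compound is needed for the effect), compound 2 `CCOC(=O)/C=C/c1ccccc1OC(=O)c1nc(C)c(C)nc1C` gives 108000 nM and compound 1 `CCOC(=O)/C=C/c1cc(OC)ccc1OC(=O)c1nc(C)c(C)nc1C` gives 105000 nM, so these two values cannot be told apart. Compound 3 `CCOC(=O)/C=C/c1cc(Cl)ccc1OC(=O)c1nc(C)c(C)nc1C` has not yet been measured. Its structure is that of compound 2 with a single change: chloro in place of hydrogen on an aromatic carbon. Within the data shown here, only one measured step bears on this change. It replaces methoxy with hydrogen on that same aromatic carbon, and it amounts to a 1.0-fold higher number from compound 1 to compound 2 (0.01 log units; within the scatter). Swapping the group at this place has so far made no visible difference, so no step beyond the scatter is expected for chloro. Among the measured compounds shown here, this is thin evidence, though, as it rests on one step and no chloro compound has been measured. The expected change is a 1.2-fold lower number from compound 2 to compound 3 (0.08 log units; within the scatter). Compound 3 is therefore estimated at 90000 nM, with an expected range from 45000 nM to 170000 nM.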

Compound 3, half-maximal effective concentration: 36100 nM
Compound 3: middle estimate off by 2.5-fold (0.40 log units), on the high side; measured number below the stated range.
By their numbers in this assay, from the lowest: compound 3; then compounds 1 and 2 (each within the scatter of the next).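

In this assay, this position proves not to be indifferent to what sits on it: chloro in place of hydrogen gives a 3.0-fold lower number from compound 2 to compound 3 (0.48 log units; beyond the scatter), and chloro in place of methoxy gives a 2.9-fold lower number from compound 1 to compound 3 (0.46 log units; beyond the scatter), both modest but beyond the scatter. Hydrogen and methoxy had given values that could not be told apart, so the earlier pair gave no sign that a change here could move the number at all; of these three compounds, only compound 3 stands apart, needing less compound for the effect. No measurement available here accounts for why chloro differs from both hydrogen and methoxy.

As far as these compounds go, it remains open whether fluoro or bromo at this place would behave like chloro, and whether an amine or a carboxylic acid would shift the number in either direction. From the compounds shown here alone, it is also open whether chloro would give a similar step on another carbon of this ring.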